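The source may hold more compounds than are shown below. What is called first, only, known or untested is meant among the compounds shown, and "the series" means these compounds.

In a functional assay on MCF7 cells (Homo sapiens) for cytotoxicity, read by sulforhodamine B assay, with a stated time of 48 h (a higher number here means a weaker inhibitor, a lower number a stronger inhibitor), compound 1 (`COc1cc(/C=C/C(=O)c2cccc(-c3cccc(F)c3)c2)ccc1O`) gives 14200 nM as its reading, and compound 3 (`COc1ccc(-c2cc(C(=O)/C=C/c3cccc(OC)c3OC)ccc2N)cc1OC`) gives 10200 nM as its reading, two values that lie within the usual scatter of each other. Compound 2 (`COc1ccc(/C=C/C(=O)c2cccc(-c3cccc(F)c3)c2)cc1O`) stands apart from them: its entry reads "not determined" (no result reported) and so it has no single number, which leaves no starting value on the scale. Compound 4 (`COc1ccc(/C=C/C(=O)c2cccc(-c3cccc(F)c3)c2)cc1OC`) has yet to be measured. The structural change is methyl in place of hydrogen on an oxygen on an aromatic ring (methyl in place of hydrogen on an oxygen on an aromatic ring, or hydroxy to methoxy). No measured step of this kind exists among these compounds, and without a value for compound 2 the size of the change cannot be read from the data. The expectation in this assay is therefore a step no larger than the scatter, with no favoured direction. Among the measured compounds shown here, the only guide to the level is the pair of readings already in hand, compound 1 at 14200 nM and compound 3 at 10200 nM on the same scale. For compound 4 the estimated value is 12000 nM with an expected range from 5000 nM to 30000 nM in this read-out.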

Compound 4, half-maximal inhibitory concentration: 4620 nM
Beside the measured number, compound 4's estimate is 2.6-fold (0.41 log units) above it; measured number below the stated range.
By their numbers in this assay, from the lowest: compound 4; then compounds 3 and 1 (each within the scatter of the next).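

In this assay, among the compounds shown here, the change of hydroxy to methoxy now has a size for the first time, with methyl in place of hydrogen on an oxygen on an aromatic ring giving a 3.1-fold lower number from compound 1 to compound 4 (0.49 log units; beyond the scatter), and the direction is towards a stronger inhibitor. From the compounds shown here alone, this is one step at one oxygen, and the same change at the other oxygen, which links compound 2 to compound 4, cannot be read: compound 2 has no single number, so it remains unknown whether both oxygens respond alike. No information is available here that would explain the size or direction of this step.

The compounds shown leave open whether the trend would continue with a longer chain on that oxygen, such as ethoxy, or whether a different group there, such as an amine, would keep the lower number seen for compound 4. They also leave open whether the step would hold on a core without the fluorine of compound 1 and compound 4.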